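Configuration change at the ring carbon in the iminosugar series

A few compounds are considered here, and "the series" means these few. Any claim that something is new, unique, unknown or untested is made for them only; others in the source may bear on it.

Compound 1 `Cc1cccc(-c2ccc(COCCCCCN3C[C@H](O)[C@@H](O)[C@H](O)[C@H]3CO)cc2)c1` gives 100 nM in an assay on isolated protein for inhibition of ceramide glucosyltransferase (Homo sapiens); on this read-out lower numbers stand for stronger inhibition and higher numbers for weaker inhibition. Going by the values given here, compound 2 `COc1ccc(-c2ccc(COCCCCCN3C[C@H](O)[C@@H](O)[C@H](O)[C@H]3CO)cc2)cc1` gives 25 nM; the step of a 4.0-fold lower number from compound 1 to compound 2 (0.60 log units; beyond the scatter) is the only single-point change measured. Compound 3 `OC[C@@H]1[C@@H](O)[C@H](O)[C@@H](O)CN1CCCCCOCc1ccc(-c2ccccc2)c(C(F)(F)F)c1` gives 25 nM, level with compound 2 at the digits shown, the two together the lowest of the three numbers, and well ahead of compound 1. Compound 4 `OC[C@H]1[C@@H](O)[C@H](O)[C@@H](O)CN1CCCCCOCc1ccc(-c2ccccc2)c(C(F)(F)F)c1` differs from compound 3 only in configuration: the two compounds have the same atoms and bonds and differ only in configuration as drawn: 1 of 4 stereo elements differ; a stereocentre at a saturated ring carbon is drawn R in compound 3 and S in compound 4. Among the compounds with values here, no measured step concerns a change of configuration, so the aryl step gives no direct guide. An inversion at the ring carbon may alter the number in either direction; a modest shift is expected, a 1.6-fold higher number from compound 3 to compound 4 (0.20 log units; within the scatter). Compound 4 is therefore estimated at 40 nM, within 10 nM to 200 nM.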

Compound 4, half-maximal inhibitory concentration: 3 nM
Beside the measured number, compound 4's estimate is 13-fold (1.12 log units) above it; the measured number lies below the stated range.
By their numbers in this assay, from the lowest: compound 4; then compounds 2 and 3 (each within the scatter of the next); then compound 1.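

Inverting this saturated ring carbon from R to S gives an 8.3-fold lower number from compound 3 to compound 4 (0.92 log units; beyond the scatter) in this assay; the earlier compounds varied only the aryl portion and gave no reading of configuration. This ring carbon is therefore a sensitive position in the series, and the shift can be assigned to that centre alone because nothing else separates the pair: the fact that compounds 3 and 4 differ only in the configuration as drawn

Going by these compounds alone, only this one pair tests the inversion, so a like step with the aryl groups of compound 1 or compound 2 remains open. Also open, on these data alone, is whether the S configuration keeps its advantage with a nitrile in place of trifluoromethyl, or with a longer chain.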